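Swapping the Group on the Ring Nitrogen of Compound 2

The compounds below may be only part of what the source reports. "The series", "measured", "known", "first", "only" and "open" are said of these compounds alone.

Measured compounds:
compound 1 `CCC(CC)n1c(-c2ccc(OCc3c(-c4c(Cl)cccc4Cl)noc3C(C)C)cc2F)nc2ccc(C(=O)O)cc21` > 10000 nM
compound 2 `CC(=O)N1CCC(n2c(-c3ccc(OCc4c(-c5c(Cl)cccc5Cl)noc4C(C)C)cc3)nc3ccc(C(=O)O)cc32)CC1` > 10000 nM
compound 3 `CC(C)c1onc(-c2c(Cl)cccc2Cl)c1COc1ccc(-c2nc3ccc(C(=O)O)cc3n2C)cc1Cl` 2450 nM

All three share a core that carries a carboxylic acid and differ mainly in what sits on the aromatic nitrogen and on the middle phenyl ring. In an assay on HEK-293T cells for antagonist activity at vitamin D3 receptor (Homo sapiens), read by a luciferase reporter, with a stated time of 24 h (on this read-out higher numbers stand for weaker inhibition and lower numbers for stronger inhibition), compound 2 gives > 10000 nM, which is a limit of the assay rather than a number. Compound 1 also gives a limit, > 10000 nM. Compound 2 therefore stands at the limit of > 10000 nM in this assay, at which 2 of the 3 values shown sit. Compound 3, which carries a methyl group on the aromatic nitrogen, gives 2450 nM in this assay, a measured number.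

The unmeasured compound 4 `CC(C)c1onc(-c2c(Cl)cccc2Cl)c1COc1ccc(-c2nc3ccc(C(=O)O)cc3n2Cc2ccc(F)cc2)cc1` differs from compound 2 in one place:
4-fluorobenzyl in place of 1-acetylpiperidin-4-yl on an aromatic nitrogen

For the measured compounds named here, no step between measured compounds is available, so the size of this change can only be guessed. Compound 3 shows that a small group on the aromatic nitrogen can give a measurable number, while compound 1 and compound 2 with larger groups sit at the limit. For compound 4 a move toward measurable but still weak inhibition is expected, an at least 1.6-fold lower number from compound 2 to compound 4 (0.22 log units; that floor lies within the scatter), and the estimate in this assay is 6000 nM, between 1500 nM and 20000 nM.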

Compound 4, half-maximal inhibitory concentration: 1140 nM
Compound 4: the middle estimate sits 5.3-fold (0.72 log units) above what was measured; the measured number lies below the stated range.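

In this assay, the change of 1-acetylpiperidin-4-yl to 4-fluorobenzyl on the aromatic nitrogen, with the rest of the structure the same, gives an at least 8.7-fold lower number from compound 2 to compound 4 (0.94 log units; beyond the scatter). For the compounds shown here, this is the first comparison here that isolates this position, and it shows that the identity of the group on this nitrogen can by itself move the read-out beyond the usual scatter. The two groups hardly differ in heavy-atom count, 9 leaving and 8 entering, so a group of this count need not leave a compound at the limit, although compound 2 shows that it can, and compound 2 gives only a limit of the assay rather than a number, so the step has a floor and no exact size: the limit of > 10000 nM in this assay, at which 2 of the 4 values shown sit.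

The compounds shown leave open which part of the swap carries the step: the fluorine, the aromatic ring or the loss of the acetyl group, a question that plain benzyl, cyclohexyl or piperidin-4-yl on the same nitrogen would help to separate. They also leave open whether 2-phenylethyl, which has a longer chain, would move the number further in either direction.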